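The compounds below may be only part of what the source reports. "The series", "measured", "known", "first", "only" and "open" are said of these compounds alone.

Working notes on the series.

Compound 1 `Nc1nc(-c2cccc(CO)c2)nc2sc(-c3ccccc3)nc12` in an assay on CHO cells for displacement of a labelled ligand from adenosine receptor A1 (Homo sapiens), read by scintillation counting, with a stated time of 3 h (on this read-out lower numbers stand for stronger inhibition and higher numbers for weaker inhibition), gives 32 nM. Compound 2 `COc1cccc(-c2nc(N)c3nc(-c4ccccc4)sc3n2)c1` differs from compound 1 by methoxy in place of hydroxymethyl on an aromatic carbon, and in this assay compound 2 gives 176 nM; the step is a 5.5-fold higher number from compound 1 to compound 2 (0.74 log units; beyond the scatter).

Compound 3 `Nc1nc(-c2ccc(CO)cc2)nc2sc(-c3ccco3)nc12` carries a different core; how it differs from the core of compound 1 is not broken down here. In this assay compound 3 gives 77.7 nM, which places it between the two numbers already in hand.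

Compound 4 `COc1ccc(-c2nc(N)c3nc(-c4ccco4)sc3n2)cc1` has not yet been measured. It differs from compound 3 by methoxy in place of hydroxymethyl on an aromatic carbon. This is the same kind of change as that from compound 1 to compound 2, but not the same: in the earlier pair the affected aromatic carbon is meta to a large group, while in compound 3 and compound 4 it is para to a large group. For the measured compounds named here, only one measured example of this change exists, so the expectation rests on that single step.

For compound 4 the expected step is a 4.5-fold higher number from compound 3 to compound 4 (0.65 log units; beyond the scatter), a weakening of binding set against the measured step of a 5.5-fold higher number from compound 1 to compound 2 (0.74 log units; beyond the scatter), with the range widened because the place of the change and the core are not those of the earlier pair. Compound 4 is therefore estimated at 350 nM, with a band from 140 nM to 900 nM.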

Compound 4, inhibition constant: 47.7 nM
Compound 4: the middle estimate sits 7.3-fold (0.87 log units) above what was measured; the measured number lies below the stated range.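

Methoxy in place of hydroxymethyl on an aromatic carbon does not carry a single step size from one core to the other in this assay: the same change on two cores in this assay, a 5.5-fold higher number (0.74 log units; beyond the scatter) from compound 1 to compound 2 and a 1.6-fold lower number (0.21 log units; within the scatter) from compound 3 to compound 4, 9.0-fold (0.95 log units) apart, beyond the scatter of two such steps. On the core of compound 3, the new step, a 1.6-fold lower number from compound 3 to compound 4 (0.21 log units; within the scatter), leaves no difference that can be read, so the weakening seen with the earlier pair cannot be taken as a general result of this change in the series. What this does not show is the source of the gap, since the two pairs differ in the core and also in the place of the change, which in the new pair is para to a large group and in the earlier pair is not, and with one pair on each core neither difference can be singled out.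

The compounds shown leave open whether the gap follows the core or the place on the ring, a question that would need both groups at both places on each core. Also open, on these data alone, is how other groups at the same place, such as an aminomethyl or a carboxylic acid, would read in this assay on either core.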